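Para-substituent variation on the shared phenyl of the pyrazoline series

This account rests on a few compounds, and the source may have more. Where it says the series, first, only, none or still open, it means among the compounds named here.

Measured so far:
compound 1 `COc1ccc(C2=NN(c3nc(-c4ccc(Br)cc4)cs3)C(c3cccs3)C2)cc1` gives 5870 nM
compound 2 `Cc1ccc(C2=NN(c3nc(-c4ccc(Br)cc4)cs3)C(c3cccs3)C2)cc1` gives 18400 nM

Both numbers come from a functional assay on WM 266-4 cells (Homo sapiens) for antiproliferative activity, read by MTT assay, with a stated time of 48 h; on this read-out higher numbers stand for weaker inhibition and lower numbers for stronger inhibition. Among the measured compounds shown here, compound 2 stands at the higher of the two numbers, with compound 1 as its only neighbour, and the one step measured, a 3.1-fold higher number from compound 1 to compound 2 (0.50 log units; beyond the scatter), lies beyond the scatter.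

Compound 3 `Brc1ccc(C2=NN(c3nc(-c4ccc(Br)cc4)cs3)C(c3cccs3)C2)cc1` is the next member. Relative to compound 2 the change is bromo in place of methyl on an aromatic carbon; cut one bond further out it reads 4-methylphenyl to 4-bromophenyl, at the position para to a large group.

For the measured compounds named here, no measured pair shows bromo against methyl, so nothing bears directly on the step. Going by the values given here, the only step in hand, a 3.1-fold higher number from compound 1 to compound 2 (0.50 log units; beyond the scatter), concerns methoxy against methyl at the same place and was modest. On that basis the step to compound 3 is expected to be small, and the direction is uncertain; a move back toward compound 1 is as plausible as none. The step from compound 2 to compound 3 is estimated as a 1.7-fold lower number from compound 2 to compound 3 (0.22 log units; within the scatter) in this assay. Compound 3 is accordingly expected to give about 11000 nM, within the range 3500 nM to 35000 nM.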

Compound 3, half-maximal inhibitory concentration: 13000 nM
For compound 3 the middle estimate is 1.2-fold (0.07 log units) below the measured one, and the stated range covers the measured number.
By their numbers in this assay, from the lowest: compound 1; then compounds 3 and 2 (each within the scatter of the next).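

In this assay, bromo and methyl at this position, para to a large group, are not separated: a 1.4-fold lower number from compound 2 to compound 3 (0.15 log units; within the scatter) gives no ranking between the two groups. Set against methoxy at the same place, bromo gives a 2.2-fold higher number from compound 1 to compound 3 (0.35 log units; beyond the scatter), which lies beyond the scatter as the step from methoxy to methyl did, so among these three compounds compound 1 alone stands apart, with the lowest number. No measurement at hand offers an explanation for the separate place of compound 1.

On these data alone, it remains open whether the lower number belongs to methoxy alone or would also appear with another group at this place, such as an amine, a hydroxyl or a carboxylic acid, and whether a longer chain such as ethoxy would keep it. Also open, as far as these compounds go, is whether these exchanges would read the same with a change elsewhere on the shared core, since all three compounds carry the same remainder of the structure.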